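One Methyl Added to the Chain of Compound 2

The compounds below may be only part of what the source reports. "The series", "measured", "known", "first", "only" and "open" are said of these compounds alone.

- compound 1 `CCCCCC1(O)C(=O)Nc2ccc(Nc3ccc(C)cc3)cc21` gives > 100000 nM (a limit)
- compound 2 `CCCCC1(O)C(=O)Nc2ccc(Nc3ccc(F)cc3)cc21` gives 32500 nM (a number)

Going by the values given here, in a functional assay on NCI-H460 cells (Homo sapiens) for antiproliferative activity, read by MTT assay, with a stated time of 48 h (on this read-out higher numbers stand for weaker inhibition and lower numbers for stronger inhibition), compound 2 gives 32500 nM as the only true number so far. For compound 1 the value > 100000 nM is a limit of the assay and not a number. Compound 3 `CCCCCC1(O)C(=O)Nc2ccc(Nc3ccc(F)cc3)cc21` carries a single change (methyl in place of hydrogen on a saturated chain carbon, four bonds along the chain from a saturated ring carbon), methyl in place of hydrogen on a saturated chain carbon. Among the compounds with values here, no measured pair shows this change alone, so in this assay only a small shift toward weaker inhibition is expected, about the size of the usual scatter. The expected move is a 1.4-fold higher number from compound 2 to compound 3 (0.14 log units; within the scatter) (an estimate). Estimated for compound 3 is 45000 nM (expected range 15000 nM to 100000 nM).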

Compound 3, half-maximal inhibitory concentration: > 100000 nM
Compound 3: a limit, no number; the forecaster's own chance of this, stated with the estimate: 25%; middle value at least 2.2-fold (0.34 log units) from the limit.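

In this assay, a single methyl in place of hydrogen on a saturated chain carbon, four bonds along the chain from a saturated ring carbon, gives an at least 3.0-fold higher number from compound 2 to compound 3 (0.48 log units; beyond the scatter), so this chain end does not tolerate even one added carbon without a loss of inhibition. From the compounds shown here alone, the value of compound 3 is a limit of the assay and not a number, so the true size of the step stays unknown: the limit of > 100000 nM in this assay, at which 2 of the 3 values shown sit. The step from compound 1 to compound 3 cannot be read, as both values are limits.

Still open, going by these compounds, is how a shorter chain, such as propyl, would compare with compound 2. On these data alone, a chain of the same length ending in an amine is also open.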